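A few compounds are considered here, and "the series" means these few. Any claim that something is new, unique, unknown or untested is made for them only; others in the source may bear on it.

Series notes. Compound 1 `Nc1scc(CN2CCN(c3ccc(OC(F)(F)F)cc3)CC2)c1C(=O)c1ccc(Cl)cc1` stands at the lower end of the two measured numbers: in a functional assay on CHO cells with adenosine receptor A1 (Homo sapiens) as the target, read by cAMP accumulation and immunoassay, with a stated time of 6 min, tested at 1 uM (on this read-out higher numbers stand for a weaker effect at the one concentration tested and lower numbers for a stronger effect), compound 1 gives -51%. Compound 2 `Nc1scc(CN2CCN(c3cccc(F)c3)CC2)c1C(=O)c1cccc(C(F)(F)F)c1` in this assay gives -35%, a number higher than that of compound 1 by a margin beyond the usual scatter, so compound 1 is the stronger of the two on this read-out.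

Compound 3 `Nc1scc(CN2CCN(c3cc(Cl)ccc3Cl)CC2)c1C(=O)c1ccc(Cl)cc1` remains to be measured in this assay. It differs from compound 1 in one place: 2,5-dichlorophenyl in place of 4-(trifluoromethoxy)phenyl on an amine nitrogen in a ring. Among the measured compounds shown here, no measured pair isolates this exchange, so no comparable step is available and the effect has to be judged without one. A step of small to moderate size toward a weaker effect is expected, close to the edge of the scatter rather than far beyond it. The step of a number 11 percentage points higher from compound 1 to compound 3 (beyond the scatter) is the expected change. Compound 3 is estimated at -40% in this assay, with a range from -65% to -15%.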

Compound 3, a percentage reported as activity, at one concentration (the size of the read-out at that concentration, not a potency): -42%
Estimate against measurement, compound 3: 2 percentage points above; low and high end bracket the measured number.
By their numbers in this assay, from the lowest: compounds 1, 3 and 2 (each within the scatter of the next, the first and the last beyond it).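

In this assay, among the compounds shown here, the first single-place step is 2,5-dichlorophenyl in place of 4-(trifluoromethoxy)phenyl on an amine nitrogen in a ring, and it gives (a number 9 percentage points higher from compound 1 to compound 3 (within the scatter)). At this position, then, the read-out does not separate these two substituted phenyl groups, even though the entering group carries chlorine where the leaving group carries trifluoromethoxy, and it has no hydrogen-bond acceptor. Nothing measured accounts for this lack of separation.

The compounds shown leave open whether this insensitivity extends beyond these two groups, for example to an unsubstituted phenyl, a pyridine ring or a phenyl bearing a carboxylic acid. They also leave open whether the same exchange gives a comparable step when the rest of the shared core carries the groups of compound 2.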